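Clearance notes: fluoro replaces trifluoromethyl

The compounds below may be only part of what the source reports. "The series", "measured", "known", "first", "only" and "open" are said of these compounds alone.

In an ADME assay on the whole organism for pharmacokinetics, with Rattus norvegicus as the target, at a dose of 3 mg/kg by the intravenous route (on this read-out higher numbers stand for fast clearance and lower numbers for slow clearance), compound 3 `COC(=O)N[C@H](C(=O)N1CCC[C@H]1C(=O)Nc1ccc([C@@H]2CC[C@@H](c3ccc(NC(=O)[C@@H]4CCCN4C(=O)[C@@H](NC(=O)OC)C(C)C)cc3)N2c2ccc(C(F)(F)F)cc2)cc1)C(C)C` gives 20 mL/min/kg, the second highest of the three numbers. Compound 2 `COC(=O)N[C@H](C(=O)N1CCC[C@H]1C(=O)Nc1ccc([C@H]2CC[C@H](c3ccc(NC(=O)[C@@H]4CCCN4C(=O)[C@@H](NC(=O)OC)C(C)C)cc3)N2c2ccc(C(F)(F)F)cc2)cc1)C(C)C` gives 4.83 mL/min/kg and compound 1 `COC(=O)N[C@H](C(=O)N1CCC[C@H]1C(=O)Nc1ccc([C@@H]2CC[C@@H](c3ccc(NC(=O)[C@@H]4CCCN4C(=O)[C@@H](NC(=O)OC)[C@@H](C)OC)cc3)N2c2ccc(F)cc2)cc1)[C@@H](C)OC` gives 56.7 mL/min/kg. Going by the values given here, the only measured step, a 4.1-fold higher number from compound 2 to compound 3 (0.62 log units; beyond the scatter), rests on the fact that compounds 2 and 3 differ only in the configuration as drawn and does not concern the substituent that changes here. Compound 4 `COC(=O)N[C@H](C(=O)N1CCC[C@H]1C(=O)Nc1ccc([C@@H]2CC[C@@H](c3ccc(NC(=O)[C@@H]4CCCN4C(=O)[C@@H](NC(=O)OC)C(C)C)cc3)N2c2ccc(F)cc2)cc1)C(C)C` differs from compound 3 as follows: fluoro in place of trifluoromethyl on an aromatic carbon. Among the compounds with values here, compound 1 carries the same 4-fluorophenyl with a different side chain, and its number stands above that of compound 3, but no single-change step joins compound 1 to compound 4, so no measured step bears directly on this change. For compound 4 the expected value in this assay is 30 mL/min/kg, with a range from 12 mL/min/kg to 70 mL/min/kg. That estimate means an expected step of a 1.5-fold higher number from compound 3 to compound 4 (0.18 log units; within the scatter), upward but uncertain.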

Compound 4, clearance: 15 mL/min/kg
Compound 4: the middle estimate sits 2.0-fold (0.30 log units) above what was measured, and the stated range covers the measured number.
By their numbers in this assay, from the lowest: compound 2; then compounds 4 and 3 (each within the scatter of the next); then compound 1.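

Going by these compounds alone, on the aromatic carbon para to a large group, fluoro in place of trifluoromethyl gives a 1.3-fold lower number from compound 3 to compound 4 (0.12 log units; within the scatter) in this assay and is the first measured step at this position. Going from 4-(trifluoromethyl)phenyl to 4-fluorophenyl, with one heavy atom entering where four leave, therefore gives no step beyond the scatter in this configuration and with this side chain. Nothing in the evidence at hand bears on this substituent change.

Still open, as far as these compounds go, is whether a nitrile, an amine or a carboxylic acid at this position would give a step beyond the scatter. Also open, from the compounds shown here alone, is whether the same exchange reads alike in the configuration of compound 2.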